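A few compounds are considered here, and "the series" means these few. Any claim that something is new, unique, unknown or untested is made for them only; others in the source may bear on it.

In a functional assay on A549 cells (Homo sapiens) for cytotoxicity, read by MTT assay, with a stated time of 72 h (a lower number here means a stronger inhibitor, a higher number a weaker inhibitor), compound 1 `CC[S+]([O-])CCCCN=C=S` gives 10200 nM, while compound 2 `COc1ccc(C[S+]([O-])CCCCN=C=S)cc1` gives 32600 nM. Among the measured compounds shown here, compound 1 therefore holds the lower of the only two numbers available, and the gap between the two lies beyond the usual scatter of repeated measurements. Compound 3 `[O-][S+](CCCCN=C=S)Cc1ccco1` has not yet been measured in this assay. It differs from compound 1 in one place: furan-2-yl in place of methyl on a saturated chain carbon bound to a sulfur, which puts furan-2-yl in place of methyl on a saturated chain carbon bound to a sulfur. For the measured compounds named here, no measured pair shows a change of this kind, so the expectation rests on little evidence. Going by the values given here, the only anchors are compound 1 at 10200 nM and compound 2 at 32600 nM. A small move towards a higher number, meaning a weaker inhibitor, is expected, and it may not clear the scatter. The expected size of the change is a 1.7-fold higher number from compound 1 to compound 3 (0.22 log units; within the scatter). For compound 3 the estimated value is 17000 nM, with an expected range from 7000 nM to 40000 nM.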

Compound 3, half-maximal inhibitory concentration: 5640 nM
Beside the measured number, compound 3's estimate is 3.0-fold (0.48 log units) above it; measured number outside the range, below it.
By their numbers in this assay, from the lowest: compounds 3 and 1 (each within the scatter of the next); then compound 2.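

In this assay the change to furan-2-yl in place of methyl on a saturated chain carbon bound to a sulfur gives a 1.8-fold lower number from compound 1 to compound 3 (0.26 log units; within the scatter) and so leaves compound 3 and compound 1 indistinguishable by this read-out. Among the compounds shown here, this is the first step read at this position, and it shows that a group of five heavy atoms, with a five-membered aromatic ring and a hydrogen-bond acceptor, can replace a single carbon there with no difference that clears the scatter. Nothing among the data shown bears on what lies behind this result.

On these data alone, a single step cannot tell whether this position would accept any group or only furan-2-yl, so it remains open how thiophen-2-yl, an unsubstituted phenyl, an amine or a carboxylic acid would read in its place. As far as these compounds go, it also remains open whether a longer chain at this place would keep the number level with those of compound 1 and compound 3 or move it beyond the scatter.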